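Aryl ether swap at the oxygen: fluorophenyl to pyridinyl

This account rests on a few compounds, and the source may have more. Where it says the series, first, only, none or still open, it means among the compounds named here.

Compound 1 `C=CC(=O)NCc1coc(-c2c(N)ncnc2Nc2ccc(Oc3cccc(F)c3)c(Cl)c2)n1` and compound 2 `C=CC(=O)NCc1coc(-c2c(N)ncnc2Nc2ccc(Oc3ccc(F)cc3)c(Cl)c2)n1` differ only in the group on the oxygen on an aromatic ring. In an in vitro ADME assay on microsomes from liver (Canis lupus familiaris) for metabolic stability, tested at 5 uM (a lower number here means that the compound disappears faster, a higher number that the compound lasts longer), compound 1 reaches > 1.66 h, which is a limit of the assay and not a number. Compound 2 likewise stands at > 1.66 h, again a limit. The step that the two limits leave unreadable from compound 1 to compound 2 is therefore unreadable, with the limit of > 1.66 h in this assay, at which 2 of the 2 values shown sit, as the only anchor in this series. Compound 3 `C=CC(=O)NCc1coc(-c2c(N)ncnc2Nc2ccc(Oc3cccnc3)c(Cl)c2)n1` differs from compound 2 by pyridin-3-yl in place of 4-fluorophenyl on an oxygen on an aromatic ring. Within the data shown here, no measured step bears on this exchange, and the two limits give no direction. Compound 3 is expected to hold 1.5 h (range 0.5 h to 3.5 h). The expected step of an at least 1.1-fold lower number from compound 2 to compound 3 (0.04 log units; that floor lies within the scatter) stays within the scatter.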

Compound 3, half-life: 0.65 h
The estimate for compound 3 lay 2.3-fold (0.36 log units) above the measured number; low and high end bracket the measured number.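

In this assay, the group on this oxygen proves able to move the half-life: pyridin-3-yl in place of 4-fluorophenyl gives an at least 2.5-fold lower number from compound 2 to compound 3 (0.40 log units; beyond the scatter), and in place of 3-fluorophenyl it gives an at least 2.5-fold lower number from compound 1 to compound 3 (0.40 log units; beyond the scatter). Among these compounds, these are the first readable steps at this position, as the step between the two fluorophenyl compounds cannot be read. Their full size stays unknown, because both fluorophenyl compounds rest on a limit of the assay: the limit of > 1.66 h in this assay, at which 2 of the 3 values shown sit.

As far as these compounds go, the exchange removes fluorine and brings in a ring nitrogen together, so the share of each stays open. An unsubstituted phenyl on the same oxygen would separate the two.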